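A few compounds are considered here, and "the series" means these few. Any claim that something is new, unique, unknown or untested is made for them only; others in the source may bear on it.

In a functional assay on the whole organism (strain Kunming) with Mus musculus as the target, in the maximal electroshock model, with a stated time of 0.5 h (on this read-out lower numbers stand for an effect already at smaller amounts and higher numbers for an effect only at larger amounts of compound), compound 2 `O=C1NC2(CC2c2ccc3cccc(OCc4ccccc4)c3n2)C(=O)N1c1ccc(F)cc1` gives 300 mg/kg. Compound 1 `O=C1NC2(CC2c2ccc3cccc(OCc4ccccc4)c3n2)C(=O)N1c1ccc(Cl)cc1` gives 300 mg/kg, and compound 3 `O=C1NC(=O)C2(CC2c2ccc3cccc(OCc4ccccc4)c3n2)N1` gives 300 mg/kg; compound 2 stands level with both. Compound 4 `O=C1NC2(CC2c2ccc3cccc(OCc4ccccc4)c3n2)C(=O)N1C1CCCCC1` carries the change (cyclohexyl in place of 4-fluorophenyl on an amide-type nitrogen in a ring). Within the data shown here, two measured steps touch the same ring nitrogen: no change at the digits printed from compound 1 to compound 3 (within the scatter) and no change at the digits printed from compound 2 to compound 3 (within the scatter), while no change at the digits printed from compound 1 to compound 2 (within the scatter) concerns the aromatic ring that now leaves. Among the measured compounds shown here, all three steps stay within the scatter, so the occupant of that nitrogen has so far made no visible difference, and no step with a cyclohexyl group exists. The account therefore expects no shift beyond the scatter, a step of no change at the digits printed from compound 2 to compound 4 (within the scatter). For compound 4 the expected value is 300 mg/kg, with a range from 150 mg/kg to 600 mg/kg.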

Compound 4, minimum effective dose: 300 mg/kg
The estimate for compound 4 equals the measured number at the digits printed; the range from low to high includes it.
By their numbers in this assay, from the lowest: compounds 1, 2, 3 and 4 (each within the scatter of the next).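

In this assay, a non-aromatic ring on the amide-type nitrogen in a ring now joins the aromatic rings and hydrogen there, with no change at the digits printed from compound 2 to compound 4 (within the scatter) and no change at the digits printed from compound 1 to compound 4 (within the scatter) and also no change at the digits printed from compound 3 to compound 4 (within the scatter) for cyclohexyl. Across these four compounds, the reading at this position therefore does not separate hydrogen, 4-chlorophenyl, 4-fluorophenyl and cyclohexyl. No supporting measurement bears on this result. On these data alone, whether an amine or a carboxylic acid on this nitrogen would leave the reading unchanged stays open, as does the effect of any change elsewhere on the shared core.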